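The source may hold more compounds than are shown below. What is called first, only, known or untested is meant among the compounds shown, and "the series" means these compounds.

Working notes on the series. In a functional assay on A2780 cells (Homo sapiens) for cytotoxicity, read by sulforhodamine B assay, with a stated time of 72 h (a higher number here means a weaker inhibitor, a lower number a stronger inhibitor), compound 1 (`O=C(NCc1ccc(S(=O)(=O)c2cncc(C(F)(F)F)c2)cc1)N1Cc2ccncc2C1`) gives 10 nM, compound 2 (`O=C(NCc1ccc(S(=O)(=O)C2CCOCC2)cc1)N1Cc2ccncc2C1`) gives 35 nM and compound 3 (`CN1CCC(S(=O)(=O)c2ccc(CNC(=O)N3Cc4ccncc4C3)cc2)CC1`) gives 99 nM, the highest of the three numbers. Compound 4 (`O=C(NCc1ccc(S(=O)(=O)N2CCC[C@H](O)C2)cc1)N1Cc2ccncc2C1`) differs from compound 3 in one place, on a sulfonyl sulfur: 3-hydroxypiperidin-1-yl in place of 1-methylpiperidin-4-yl on a sulfonyl sulfur. Three measured steps at this same place bear on the change: a 3.5-fold higher number from compound 1 to compound 2 (0.54 log units; beyond the scatter), a 9.9-fold higher number from compound 1 to compound 3 (1.00 log units; beyond the scatter) and a 2.8-fold higher number from compound 2 to compound 3 (0.45 log units; beyond the scatter). All three lie beyond the scatter, so the group at this place does move the number within this small set. None of them involves the 3-hydroxypiperidin-1-yl group, and the data hold no direct measure of it. With compound 3 at the top of the measured range, a move towards a lower number is the more likely direction, of about the size of the step between compound 2 and compound 3. The expected step is a 3.0-fold lower number from compound 3 to compound 4 (0.48 log units; beyond the scatter). For compound 4 the estimated value is 33 nM, with an expected range of 9 nM to 120 nM.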

Compound 4, half-maximal inhibitory concentration: 150 nM
Estimate against measurement, compound 4: 4.5-fold (0.66 log units) below, and the stated range ends below it.
By their numbers in this assay, from the lowest: compound 1; then compound 2; then compounds 3 and 4 (each within the scatter of the next).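

In this assay, 3-hydroxypiperidin-1-yl in place of 1-methylpiperidin-4-yl gives a 1.5-fold higher number from compound 3 to compound 4 (0.18 log units; within the scatter), so this pair cannot be told apart at this place, even though only the entering group carries a hydrogen-bond donor. Going by these compounds alone, the other two comparisons do separate: a 4.3-fold higher number from compound 2 to compound 4 (0.63 log units; beyond the scatter) and a 15-fold higher number from compound 1 to compound 4 (1.18 log units; beyond the scatter), the second the only step at this place printed as large, which leaves the 5-(trifluoromethyl)pyridin-3-yl group of compound 1 with the lowest number of the four. No measured evidence accompanies this result.

Still open, as far as these compounds go, is whether the hydroxyl group contributes anything here, a question that unsubstituted piperidin-1-yl and the opposite configuration at the hydroxyl-bearing carbon would address. Also open, from the compounds shown here alone, is whether a pyridin-3-yl group without the trifluoromethyl group keeps the number of compound 1.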